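The source may report more compounds than this note shows. Statements on the series, on what has been measured and on what is new or still open speak of the compounds shown alone.

In a functional assay on MDA-MB-231 cells (Homo sapiens) for inhibition, read by MTT assay, with a stated time of 72 h (a higher number here means a weaker inhibitor, a lower number a stronger inhibitor), compound 3 (`C[C@H](NC(=O)c1cc(Cl)ccc1OCCN)C(=O)Nc1ccc([N+](=O)[O-])cc1Cl`) gives > 10000 nM as its result, which is a limit and not a number. Compound 2 (`C[C@H](NC(=O)c1cc(Cl)ccc1OCCNC(=O)OC(C)(C)C)C(=O)Nc1ccc([N+](=O)[O-])cc1Cl`) gives > 10000 nM as its result, also a limit. Within the data shown here, the one measured step, a step that the two limits leave unreadable from compound 2 to compound 3, therefore offers no size to build on. Compound 4 (`CC[C@@H](C)[C@H](NC(=O)c1cc(Cl)ccc1OCCN)C(=O)Nc1ccc([N+](=O)[O-])cc1Cl`) brings sec-butyl in place of methyl on a saturated chain carbon bound to an amide-type nitrogen and a carbonyl carbon. Among the measured compounds shown here, compound 1 (`CC(C)[C@H](NC(=O)c1cc(Cl)ccc1OC1CCNCC1)C(=O)Nc1ccc([N+](=O)[O-])cc1Cl`), which carries a branched group on that carbon but also differs elsewhere, gives 5230 nM as the only true number here. On that single value, a modest move toward a lower number is expected, an at least 1.4-fold lower number from compound 3 to compound 4 (0.15 log units; that floor lies within the scatter) as estimated, though compound 4 may also stop at the limit. For compound 4 the estimated value is 7000 nM, with an expected range from 3000 nM to 16000 nM in this read-out.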

Compound 4, half-maximal inhibitory concentration: 6180 nM
Estimate against measurement, compound 4: 1.1-fold (0.05 log units) above; low and high end bracket the measured number.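

In this assay, sec-butyl in place of methyl on this saturated chain carbon gives the series a true number where the methyl compound gave only a limit: an at least 1.6-fold lower number from compound 3 to compound 4 (0.20 log units; that floor lies within the scatter). Only a floor can be read for this step, and its real size may be larger, because compound 3 stands at a limit: the limit of > 10000 nM in this assay, at which 2 of the 4 values shown sit.

From the compounds shown here alone, whether a straight butyl chain or a benzyl group on this carbon would read the same remains open. So does whether the other arrangement of the sec-butyl stereocentre would.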